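The source may report more compounds than this note shows. Statements on the series, on what has been measured and on what is new or still open speak of the compounds shown alone.

Among the measured compounds shown here, compound 1 `Nc1nc(Cl)c2ncn(Cc3ccccc3CCl)c2n1` is the only member of this set with a result in a functional assay on ACHN cells (Homo sapiens) for cytotoxicity, read by sulforhodamine B assay, with a stated time of 48 h (a higher number here means a weaker inhibitor of growth, a lower number a stronger inhibitor of growth), where compound 1 gives 5750 nM. Compound 2 `ClCc1ccc(Cn2cnc3ncnc(Cl)c32)cc1` was tested, but in this assay compound 2 gives "not determined" (no result reported), so compound 2 stands nowhere on the numbers. Compound 3 `ClCc1ccc(Cn2cnc3nc(Cl)nc(Cl)c32)cc1` differs from compound 2 by chloro in place of hydrogen on an aromatic carbon. For the measured compounds named here, with no measured pair sharing this change, the size and direction of any step in this assay are unknown; a step within the usual scatter or beyond it in either direction remains possible. Compound 3 is therefore expected, with wide uncertainty, to give about 5000 nM, in the range 1000 nM to 30000 nM.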

Compound 3, concentration for 50% growth inhibition: 1900 nM
Beside the measured number, compound 3's estimate is 2.6-fold (0.42 log units) above it; the range from low to high includes it.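

In this assay, among the compounds shown here, compound 2 has no number, and no step to compound 3 can be read. No measurement shown bears on the result of compound 3. Going by these compounds, whether chloro in place of hydrogen strengthens or weakens growth inhibition stays open.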